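From compound 2 to compound 3: a ring exchange

A few compounds are considered here, and "the series" means these few. Any claim that something is new, unique, unknown or untested is made for them only; others in the source may bear on it.

In a physicochemical assay for solubility, in phosphate buffer, at pH 7.4 (a lower number here means a less soluble compound, a higher number a more soluble compound), compound 1 `COc1cc(C(=O)N2CCCC2)ccc1-c1ccnc2[nH]c(C3CCOCC3)cc12` gives 15000 nM, while compound 2 `CC(C)n1cc(-c2ccnc3[nH]c(C4CCN(CC(=O)N(C)C)CC4)cc23)cnc1=O` gives 910000 nM, the higher of the two numbers and beyond the scatter. Compound 3 `CCn1cc(-c2ccnc3[nH]c(C4CCN(CC(=O)N(C)C)CC4)cc23)ccc1=O` differs from compound 2 in one place, on an aromatic carbon opposite the ring nitrogen: a group of 9 heavy atoms (7 carbon, 1 nitrogen, 1 oxygen; one six-membered aromatic ring with 1 hetero atom) in place of a group of 10 heavy atoms (7 carbon, 2 nitrogen, 1 oxygen; one six-membered aromatic ring with 2 hetero atoms), on an aromatic carbon. Within the data shown here, no step between measured compounds speaks to this change, so the expectation stays near compound 2 at 910000 nM. The expected step is a 1.3-fold lower number from compound 2 to compound 3 (0.11 log units; within the scatter), an estimate that lies within the scatter. In this assay the estimated value for compound 3 is 700000 nM, with a range of 250000 nM to 1500000 nM.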

Compound 3, solubility: > 1000000 nM
Compound 3: only a limit was reported (the forecaster's own chance of this, stated with the estimate: 15%); at least 1.4-fold (0.15 log units) between middle value and limit.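

Among these compounds, this is the first step at this position, on an aromatic carbon opposite the ring nitrogen, and it reads as an at least 1.0-fold higher number from compound 2 to compound 3 (0.04 log units; that floor lies within the scatter), a floor that lies within the scatter. The value of compound 3 is a limit and not a number, so the ring with 1 hetero atom in place of the ring with 2 hetero atoms shows no drop, and the size of any rise stays unread: the limit of > 1000000 nM in this assay, at which 1 of the 3 values shown sits.

The compounds shown leave open how a phenyl ring or an amine at this position would read in this assay. They also cannot separate the change in ring hetero atoms from the change in the carbon count of the group.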